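Dimethylamino for Formylamino on the Fused Core

A few compounds are considered here, and "the series" means these few. Any claim that something is new, unique, unknown or untested is made for them only; others in the source may bear on it.

Of the compounds shown here, three have been measured in a functional assay on the whole organism with Rattus norvegicus as the target, at a dose of 40 mg/kg by the intraperitoneal route; a lower number here means less inhibition, a higher number more inhibition at the dose given (going by the name of the read-out). Compound 1 `Cc1nc2c(OCc3ccc(Cl)cc3)cccn2c1N` gives 66% in this assay. Compound 2 `Cc1nc2ccc(CCc3ccccc3)cn2c1N` gives 52% in this assay. Compound 3 `Cc1nc2c(OCc3ccccc3)cccn2c1NC=O` gives 49% in this assay, the lowest of the three numbers; its nearest neighbour is compound 2, a few points higher and within the scatter, while compound 1 stands further away, beyond the scatter. No pair among these three differs in a single place, so no step can be read from them.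

Compound 4 `Cc1nc2c(OCc3ccccc3)cccn2c1N(C)C` is the next to be measured in this assay. It differs from compound 3 as follows: dimethylamino in place of formylamino on an aromatic carbon. The change sits on an aromatic carbon of a five-membered aromatic ring with 2 nitrogen, part of a fused or bridged system of two rings.

Nothing in the measured set shows what this exchange does, since compound 1 and compound 2 carry other groups at more than one position. The step from compound 3 to compound 4 is therefore expected to be small, in no firm direction, and likely within the scatter: a number 1 percentage points higher from compound 3 to compound 4 (within the scatter). Compound 4 is accordingly estimated at 50% in this assay, with a range from 30% to 70%.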

Compound 4, a percentage reported as inhibition, in the whole organism at one dose (the size of the read-out at that dose, not a potency): 76%
Compound 4: the middle estimate sits 26 percentage points below what was measured, and the stated range ends below it.
By their numbers in this assay, from the lowest: compounds 3 and 2 (each within the scatter of the next); then compounds 1 and 4 (each within the scatter of the next).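

In this assay, among the compounds shown here, replacing formylamino with dimethylamino on an aromatic carbon of the five-membered aromatic ring, with the rest of the structure unchanged, gives a number 27 percentage points higher from compound 3 to compound 4 (beyond the scatter), the first single-place step and evidence that the read-out at this dose responds to the group held at this position. The heavy-atom count is the same for both groups, so that count does not separate them; the counted differences are that dimethylamino has 0 hydrogen-bond donors where formylamino has 1, and that the double bond outside aromatic rings is gone. Nothing measured here ties the step to either difference or to any other cause.

As far as these compounds go, the response of this assay to methylamino, acetylamino or a ring amine such as pyrrolidine at this aromatic carbon remains open, so a single exchange cannot yet define a trend across amino groups. Also open, from the compounds shown here alone, is whether the same exchange would give a comparable step on the structure of compound 1 or compound 2, which carry other groups elsewhere.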